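This account rests on a few compounds, and the source may have more. Where it says the series, first, only, none or still open, it means among the compounds named here.

Measured compounds:
Compound 1 `CCOC(=O)c1cnc2ccc(-c3cccc(N)c3)cc2c1`: in a functional assay on RD cells (Homo sapiens) for inhibition, read by luminescence and ATP content, with a stated time of 72 h (a lower number here means that less compound is tolerated, a higher number that more compound is tolerated), compound 1 gives > 7400 nM, a limit of the assay.
Compound 2 `CCCCc1ccc(-c2ccc3ncc(C(=O)OCC)cc3c2)cc1`: in this assay compound 2 gives > 7400 nM, likewise a limit.
Compound 3 `CCc1nc(-c2cnc3ccc(-c4cccc(N)c4)cc3c2)no1`: in this assay compound 3 gives > 7400 nM, again a limit.

Compound 3 thus stands at the limit, with no number of its own, and the two other values shown are limits as well, so the whole set amounts to the limit of > 7400 nM in this assay, at which 3 of the 3 values shown sit, and nothing more. For the measured compounds named here, the single one-place step recorded, a step that the two limits leave unreadable from compound 1 to compound 3, is left unreadable by the limits at both of its ends, so no measured size exists for any change.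

Compound 4 `CCc1nc(-c2cnc3ccc(-c4ccc(O)cc4)cc3c2)no1` differs from compound 3 in one place: 4-hydroxyphenyl in place of 3-aminophenyl on an aromatic carbon. Going by the values given here, no measured step concerns this change; the only step on record, from compound 1 to compound 3, cannot be sized. With every value in this assay sitting at the limit, the expectation for compound 4 rests on that limit alone. Compound 4 is expected to sit at the same limit in this assay, estimated at 10000 nM, with a range from 5000 nM to 30000 nM. The implied step, a step that the limit leaves unreadable from compound 3 to compound 4, is expected to be no change beyond the scatter, and the result is most likely to be reported once more only as a limit.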

Compound 4, half-maximal cytotoxic concentration: > 2500 nM
Compound 4 gave a limit, no number (the forecaster's own chance of this, stated with the estimate: 85%); the middle value lies beyond the limit too.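

In this assay compound 4 gives > 2500 nM, a limit and not a number. For the compounds shown here, compound 3 also stands at a limit, so no step from compound 3 to compound 4 can be read. The compounds shown leave open the concentration at which any of them reaches half-maximal cytotoxicity, and whether 4-hydroxyphenyl and 3-aminophenyl differ at all.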